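Prop-1-en-1-yl in place of methyl: working notes

This account rests on a few compounds, and the source may have more. Where it says the series, first, only, none or still open, it means among the compounds named here.

For the measured compounds named here, in a functional assay (aorta) with Oryctolagus cuniculus as the target (a lower number here means tighter binding, a higher number weaker binding), three compounds have numbers so far. Compound 3 (`Cc1ccnc2c1nc(C)n2Cc1ccc(-c2ccccc2C(=O)O)cc1`) has the highest number of the three at 50.1 nM and so the weakest binding here. Compound 1 (`CCCCc1nc2c(C)ccnc2n1Cc1cc(Cl)c(O)c(Cl)c1`) reads 10 nM and compound 2 (`CCCc1nc2c(Cl)ccnc2n1Cc1ccc(-c2ccccc2C(=O)O)cc1`) reads 7.94 nM in the same read-out. These two lie within the scatter of each other, and both lie beyond the scatter from compound 3.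

Compound 4 (`C/C=C/c1nc2c(C)ccnc2n1Cc1ccc(-c2ccccc2C(=O)O)cc1`) keeps everything in compound 3 except one group. It has prop-1-en-1-yl in place of methyl on an aromatic carbon between two ring nitrogen atoms (prop-1-en-1-yl in place of methyl on an aromatic carbon).

Going by the values given here, no measured pair isolates this change. Compound 1 and compound 2 carry butyl and propyl in place of that methyl, but each also differs from compound 3 elsewhere, so they offer only a loose guide. Their direction still points one way, and with only these compounds a clearly lower number is expected in this assay for the longer group. The expected size is estimated at a 5.0-fold lower number from compound 3 to compound 4 (0.70 log units; beyond the scatter) (beyond the scatter, though the estimate is uncertain). Compound 4 is estimated at 10 nM (expected range 3 nM to 32 nM).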

Compound 4, dissociation constant: 5.01 nM
Compound 4: middle estimate off by 2.0-fold (0.30 log units), on the high side; the measured number falls inside the stated range.
By their numbers in this assay, from the lowest: compounds 4, 2 and 1 (each within the scatter of the next); then compound 3.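

In this assay, prop-1-en-1-yl in place of methyl on the aromatic carbon between two ring nitrogen atoms gives a 10-fold lower number from compound 3 to compound 4 (1.00 log units; beyond the scatter), a step beyond the scatter. For the compounds shown here, the earlier compounds offered only a loose guide, since each also differs elsewhere; this pair is the first to show, with all else held constant, that the number responds to the group at this position. The pair cannot separate the added carbon atoms from the double bond outside aromatic rings, as both enter in the same change. No measurement on these compounds speaks to why the number moves.

Still open, going by these compounds, is whether the double bond matters at all: a cyclopropyl group, or a saturated propyl or butyl chain on the otherwise unchanged core of compound 4, would read on that directly. On these data alone, how far this position tolerates other groups also remains open, whether a longer chain such as pentyl, an amine or a phenyl ring.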